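This account rests on a few compounds, and the source may have more. Where it says the series, first, only, none or still open, it means among the compounds named here.

Compound 1 `CC1=CC[C@@H]([C@@](C)(O)CCCC(C)(C)NC(=S)N/N=C\c2ccccc2)CC1`: > 100000 nM
Compound 2 `CC1=CC[C@@H]([C@@](C)(O)CCCC(C)(C)NC(=S)N/N=C\c2ccc(O)cc2)CC1`: > 100000 nM
Compound 3 `CC1=CC[C@@H]([C@@](C)(O)CCCC(C)(C)NC(=S)N/N=C\c2cccc(Cl)c2)CC1`: 56300 nM
Compound 4 `CC1=CC[C@@H]([C@@](C)(O)CCCC(C)(C)NC(=S)N/N=C\c2ccc(Cl)cc2)CC1`: not yet measured

Among the measured compounds shown here, in a functional assay on K562 cells (Homo sapiens) for cytotoxicity, read by sulforhodamine B assay (on this read-out lower numbers stand for higher toxicity in this test and higher numbers for lower toxicity in this test), compound 3 gives 56300 nM, the only actual number so far. Compound 1 gives > 100000 nM, which is a limit of the assay. Compound 2 gives > 100000 nM, which is also a limit.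

The step to compound 4 keeps the chlorine-bearing ring on the same carbon: 4-chlorophenyl in place of 3-chlorophenyl on a carbon with a double bond to nitrogen. For the measured compounds named here, two measured steps bear on it indirectly. Adding the chloro group gave an at least 1.7-fold lower number from compound 1 to compound 3 (0.24 log units; that floor lies within the scatter), and the exchange of rings gave an at least 1.7-fold lower number from compound 2 to compound 3 (0.24 log units; that floor lies within the scatter). The step between the two compounds at the limit is a step that the two limits leave unreadable from compound 1 to compound 2. None of these steps measures a move of the chloro group, and neither floor goes beyond the scatter, so no step beyond the scatter is expected in this assay. The estimated step is a 1.1-fold higher number from compound 3 to compound 4 (0.03 log units; within the scatter). For compound 4 the expected value is 60000 nM, with an estimated range of 25000 nM to 100000 nM.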

Compound 4, concentration lethal to 50% of the cells: 10300 nM
Compound 4: the middle estimate sits 5.8-fold (0.77 log units) above what was measured; measured number below the stated range.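

In this assay, among the compounds shown here, moving the chloro group alone is enough to shift the read-out: 4-chlorophenyl in place of 3-chlorophenyl on the carbon with a double bond to nitrogen gives a 5.5-fold lower number from compound 3 to compound 4 (0.74 log units; beyond the scatter), whereas the earlier steps offered only floors within the scatter. Adding the chloro group now gives an at least 9.7-fold lower number from compound 1 to compound 4 (0.98 log units; beyond the scatter), and chloro in place of hydroxy gives an at least 9.7-fold lower number from compound 2 to compound 4 (0.98 log units; beyond the scatter). Both of these steps start from a limit, so each is a floor and not a full size: the limit of > 100000 nM in this assay, at which 2 of the 4 values shown sit.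

The step between compound 1 and compound 2 cannot be read. The compounds shown also leave open whether 4-bromophenyl or 4-methoxyphenyl in place of 4-chlorophenyl would give a lower or a higher number in this assay.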